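Swapping methoxy for chloro beside the carboxylic acid

The compounds below may be only part of what the source reports. "The series", "measured", "known", "first", "only" and "open" are said of these compounds alone.

Of the compounds shown here, two have been measured in an assay on membranes from spleen (Cavia porcellus) for binding affinity to leukotriene B4 receptor (Homo sapiens); on this read-out lower numbers stand for stronger inhibition and higher numbers for weaker inhibition. Compound 1 `O=C(O)c1ccccc1-c1ccc2c(c1)OC[C@H](Cc1ccccc1)[C@H]2O` gives 120 nM, and compound 2 `COc1ccc(C(=O)O)c(-c2ccc3c(c2)OC[C@H](Cc2ccccc2)[C@H]3O)c1` gives 160 nM. Compound 2 stands at the top of these two numbers, yet the step of a 1.3-fold higher number from compound 1 to compound 2 (0.12 log units; within the scatter) is within the scatter. Compound 3 `O=C(O)c1ccc(Cl)cc1-c1ccc2c(c1)OC[C@H](Cc1ccccc1)[C@H]2O` differs from compound 2 by chloro in place of methoxy on an aromatic carbon. For the measured compounds named here, the one measured step at this aromatic carbon, hydrogen to methoxy, barely moved the number, so no step beyond the scatter is expected in this assay, in either direction. Compound 3 is therefore estimated at 140 nM, within 60 nM to 350 nM. This expectation amounts to a 1.1-fold lower number from compound 2 to compound 3 (0.06 log units; within the scatter).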

Compound 3, half-maximal inhibitory concentration: 59 nM
Estimate against measurement, compound 3: 2.4-fold (0.38 log units) above; measured number outside the range, below it.
By their numbers in this assay, from the lowest: compound 3; then compounds 1 and 2 (each within the scatter of the next).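

This position is not indifferent to its group: hydrogen to methoxy stayed within the scatter, yet chloro gives a 2.7-fold lower number from compound 2 to compound 3 (0.43 log units; beyond the scatter) and a 2.0-fold lower number from compound 1 to compound 3 (0.31 log units; beyond the scatter), both modest but beyond the scatter. On this aromatic carbon, para to a carboxy group, the number therefore depends on which group sits there, and among these three compounds only chloro stands apart. The data shown offer no explanation for this difference between chloro and methoxy. Going by these compounds, it remains open whether the lower number belongs to chloro alone or extends to fluoro, bromo or trifluoromethyl on this same carbon.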